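A few compounds are considered here, and "the series" means these few. Any claim that something is new, unique, unknown or untested is made for them only; others in the source may bear on it.

Measured so far in a functional assay on A549 cells (Homo sapiens) for antiproliferative activity, read by MTT assay, with a stated time of 72 h; a higher number here means a weaker inhibitor, a lower number a stronger inhibitor:

- compound 1 `COc1cc(-n2cnc3ccc(-c4ccccc4Cl)cc32)cc(OC)c1OC` gives > 10000 nM; this is a limit of the assay, not a number.
- compound 2 `COc1cc(-n2cnc3ccc(-c4ccc(C(C)=O)cc4)cc32)cc(OC)c1OC` gives 2510 nM.
- compound 3 `COc1ccc(-c2ccc3ncn(-c4cc(OC)c(OC)c(OC)c4)c3c2)cc1F` gives 1430 nM.

Compound 2 stands at the higher of the two numbers; the gap to compound 3 is a 1.8-fold lower number from compound 2 to compound 3 (0.24 log units; within the scatter), so the two cannot be ordered. The third value sits at the limit of > 10000 nM in this assay, at which 1 of the 3 values shown sits.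

Compound 4 `COc1cc(-n2cnc3ccc(-c4cccc(N)c4)cc32)cc(OC)c1OC` is not yet measured. Its change from compound 2: 3-aminophenyl in place of 4-acetylphenyl on an aromatic carbon.

The measured steps bearing on this position both leave 2-chlorophenyl: an at least 3.9-fold lower number from compound 1 to compound 2 (0.60 log units; beyond the scatter) and an at least 6.9-fold lower number from compound 1 to compound 3 (0.84 log units; beyond the scatter), each at least modest and beyond the scatter. Going by the values given here, the only step between two numbers, a 1.8-fold lower number from compound 2 to compound 3 (0.24 log units; within the scatter), is within the scatter. Among the compounds with values here, no measured step involves 3-aminophenyl, so there is no direct guide for this group. The expectation is therefore a step within the scatter, a 1.0-fold lower number from compound 2 to compound 4 (0.00 log units; within the scatter), in no firm direction.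

Compound 4 is estimated at 2500 nM, with a range from 800 nM to 8000 nM.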

Compound 4, half-maximal inhibitory concentration: 640 nM
Beside the measured number, compound 4's estimate is 3.9-fold (0.59 log units) above it; the whole stated range lies above it.
By their numbers in this assay, from the lowest: compound 4; then compounds 3 and 2 (each within the scatter of the next). At a limit, above all of these: compound 1.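

In this assay, going by these compounds alone, 3-aminophenyl is the first group at this position to stand apart beyond the scatter from other measured numbers: a 3.9-fold lower number from compound 2 to compound 4 (0.59 log units; beyond the scatter), and a 2.2-fold lower number from compound 3 to compound 4 (0.35 log units; beyond the scatter). The position therefore responds to the choice of aryl group even though 4-acetylphenyl and 3-fluoro-4-methoxyphenyl could not be ordered, and the lowest number so far belongs to compound 4, the only compound shown whose aryl group carries a hydrogen-bond donor. The comparison with the 2-chlorophenyl group gives an at least 15-fold lower number from compound 1 to compound 4 (1.19 log units; beyond the scatter), but the value of compound 1 is a limit of the assay: the limit of > 10000 nM in this assay, at which 1 of the 4 values shown sits.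

As far as these compounds go, whether the lower number follows the amine itself or its place on the ring stays open; each step changes both. A 4-aminophenyl or 3-hydroxyphenyl group would bear on that question.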